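The source may hold more compounds than are shown below. What is called first, only, known or untested is meant among the compounds shown, and "the series" means these compounds.

Measured so far:
- compound 1, `CN1CCC(N(C)C(=O)C2CN(S(=O)(=O)c3ccc4ccccc4c3)c3ccccc32)CC1`: 25.1 nM in a functional assay on CHO cells for antagonist activity at 5-hydroxytryptamine receptor 6 (Homo sapiens), read by FLIPR; on this read-out higher numbers stand for weaker inhibition and lower numbers for stronger inhibition
- compound 2, `Cc1c(S(=O)(=O)N2CC(C(=O)N(C)C3CCN(C)CC3)c3ccccc32)sc2ccc(Cl)cc12`: 63.1 nM in this assay

Compound 2 stands as the higher of the two numbers, the step being a 2.5-fold higher number from compound 1 to compound 2 (0.40 log units; beyond the scatter). Compound 3, `COc1ccc(S(=O)(=O)N2CC(C(=O)N(C)C3CCN(C)CC3)c3ccccc32)c(C)c1C`, differs from compound 2 by 4-methoxy-2,3-dimethylphenyl in place of 5-chloro-3-methyl-1-benzothiophen-2-yl on a sulfonyl sulfur. Going by the values given here, only that one step bears on a change at the sulfonyl sulfur, and it was modest, so a small step is expected for compound 3 in this assay, probably downward toward compound 1. Compound 3 is estimated at 40 nM, ranging from 10 nM to 160 nM. That estimate means an expected step of a 1.6-fold lower number from compound 2 to compound 3 (0.20 log units; within the scatter).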

Compound 3, inhibition constant: 100 nM
Compound 3: the middle estimate sits 2.5-fold (0.40 log units) below what was measured, and the stated range covers the measured number.
By their numbers in this assay, from the lowest: compound 1; then compounds 2 and 3 (each within the scatter of the next).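

In this assay, the single-ring 4-methoxy-2,3-dimethylphenyl on the sulfonyl sulfur cannot be told apart from the two-ring 5-chloro-3-methyl-1-benzothiophen-2-yl, with a 1.6-fold higher number from compound 2 to compound 3 (0.20 log units; within the scatter). Set against naphthalen-2-yl, the same group gives a clearer change, with a 4.0-fold higher number from compound 1 to compound 3 (0.60 log units; beyond the scatter), so at this position naphthalen-2-yl is the one group of the three that stands apart from 4-methoxy-2,3-dimethylphenyl. Nothing available explains these differences.

From the compounds shown here alone, how a pyridine ring or an unsubstituted phenyl on the sulfonyl sulfur would read remains open. Three groups also cannot show whether ring count matters here.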